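The source may report more compounds than this note shows. Statements on the series, on what has been measured and on what is new or still open speak of the compounds shown alone.

Measured so far:
compound 1, `Cc1ccc(Oc2c(/C=N\CCCCCOc3cc4oc(=O)cc(C)c4cc3Cl)c(C)nn2C)cc1`, 10300 nM in a functional assay on HepG2 cells (Homo sapiens) for antiproliferative activity, read by MTT assay, with a stated time of 72 h; a higher number here means a weaker inhibitor, a lower number a stronger inhibitor
compound 2, `Cc1nn(C)c(Oc2ccc(F)cc2)c1/C=N\CCCCCCOc1cc2oc(=O)cc(C)c2cc1Cl`, 12500 nM in this assay

The values of compound 1 and compound 2 lie within the usual scatter of each other, so neither is set apart on the numbers shown.

Compound 3, `Cc1nn(C)c(Oc2cccc(Cl)c2)c1/C=N\CCCCCCOc1cc2oc(=O)cc(C)c2cc1Cl`, follows from compound 2 by 3-chlorophenyl in place of 4-fluorophenyl on an oxygen on an aromatic ring. Within the data shown here, no measured pair shows this kind of change, so there is nothing to size it against. The expected step is a 1.1-fold lower number from compound 2 to compound 3 (0.06 log units; within the scatter), none beyond the scatter. For compound 3 the estimate in this assay is 11000 nM, with a range from 5000 nM to 25000 nM.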

Compound 3, half-maximal inhibitory concentration: 6220 nM
Estimate against measurement, compound 3: 1.8-fold (0.25 log units) above; measured number inside the range.
By their numbers in this assay, from the lowest: compounds 3, 1 and 2 (each within the scatter of the next).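

Among these compounds, compound 2 and compound 3 form the first measured pair for a change on an oxygen on an aromatic ring: 4-fluorophenoxy to 3-chlorophenoxy gives a 2.0-fold lower number from compound 2 to compound 3 (0.30 log units; within the scatter) in this assay, so this change is not set apart from the scatter. Nothing measured on these compounds accounts for the step.

The step changes both the halogen and where it sits, so 4-chlorophenyl or 3-fluorophenyl would be needed to separate the two. Going by these compounds, how an amine or a carboxylic acid on this phenyl ring would read also remains open.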